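Swapping the lactam cap on compound 1: stability expected to hold

The compounds below may be only part of what the source reports. "The series", "measured", "known", "first", "only" and "open" are said of these compounds alone.

Within the data shown here, compound 1 `CN1Cc2cc(-c3ccc(-c4cncc(NS(=O)(=O)c5ccc(F)cc5F)c4)s3)cnc2C1=O` is one of two compounds measured in an ADME assay on microsomes from liver (Homo sapiens) for metabolic stability, read by LC-MS, using NADPH, with a stated time of 30 min, tested at 3 uM; on this read-out lower numbers stand for a less stable compound and higher numbers for a more stable compound. In this assay compound 1 gives 80%, the higher of the two numbers. Compound 2 `CN1Cc2cc(-c3ccc(-c4cncc(NS(=O)(=O)c5ccccc5C(F)(F)F)c4)s3)cnc2C1=O` gives 56%; the step of a number 24 percentage points lower from compound 1 to compound 2 (beyond the scatter) comes from changing the aryl group on the sulfonyl sulfur.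

Compound 3 `O=C1NCc2ncc(-c3ccc(-c4cncc(NS(=O)(=O)c5ccc(F)cc5F)c4)s3)cc21` has not been measured. It differs from compound 1 at a different place, on the thiophene end of the shared core: a group of 10 heavy atoms (7 carbon, 2 nitrogen, 1 oxygen; one five-membered non-aromatic ring with 1 hetero atom, one six-membered aromatic ring with 1 hetero atom) in place of a group of 11 heavy atoms (8 carbon, 2 nitrogen, 1 oxygen; one five-membered non-aromatic ring with 1 hetero atom, one six-membered aromatic ring with 1 hetero atom), on an aromatic carbon. Among the measured compounds shown here, the only measured step, from compound 1 to compound 2, alters the sulfonyl aryl group and therefore does not bear on this change; no measured step touches the group that leaves or the group that enters. Without a comparable step, the expectation for compound 3 can only rest on the value of compound 1, 80%, with a change assumed to stay within the usual scatter.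

Compound 3 is therefore expected to give about 82% in this assay, within a range from 65% to 96%. That estimate means an expected step of a number 2 percentage points higher from compound 1 to compound 3 (within the scatter), which is not beyond the scatter.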

Compound 3, percent of the compound remaining: 95%
The estimate for compound 3 lay 13 percentage points below the measured number; low and high end bracket the measured number.
By their numbers in this assay, from the lowest: compound 2; then compound 1; then compound 3.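

In this assay, among these compounds, the earlier compounds differed only in the aryl group on the sulfonyl sulfur, so they said nothing about the other end of the molecule. The new result shows that this second place, on an aromatic carbon of a five-membered aromatic ring with 1 sulfur, also affects the read-out: putting the group of 10 heavy atoms, with 1 hydrogen-bond donor, in place of the group of 11 heavy atoms, with 0 hydrogen-bond donors, gives a number 15 percentage points higher from compound 1 to compound 3 (beyond the scatter). No measurement at hand explains this rise.

This single pair cannot separate the loss of one carbon from the gain of a hydrogen-bond donor, and it does not show whether the same swap would raise the number when 2-(trifluoromethyl)phenyl sits on the sulfonyl sulfur, as it does in compound 2. As far as these compounds go, how a version of this group carrying a longer chain, or an amine, would read in this place also remains open.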